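From 1H-imidazol-1-yl to methanesulfonamido in compound 2

The compounds below may be only part of what the source reports. "The series", "measured", "known", "first", "only" and "open" are said of these compounds alone.

Measured so far in a physicochemical assay for solubility, read by HPLC, with a stated time of 24 h; a lower number here means a less soluble compound, a higher number a more soluble compound:

Compound 1 `CC(=O)OC[C@H]1CN(c2ccc(-n3cc(-c4ccccn4)cn3)c(F)c2)C(=O)O1` gives 373000 nM
Compound 2 `O=C1O[C@@H](Cn2ccnc2)CN1c1ccc(-n2cc(-c3ccccn3)cn2)c(F)c1` gives 12300 nM

Within the data shown here, compound 2 holds the lower of these two numbers, and compound 1 is its only neighbour. Compound 3 `CS(=O)(=O)NC[C@H]1CN(c2ccc(-n3cc(-c4ccccn4)cn3)c(F)c2)C(=O)O1` keeps the shared core and differs from compound 2 in one place, (methanesulfonamido in place of 1H-imidazol-1-yl on a saturated chain carbon bound to a saturated ring carbon), on the same carbon that changed before.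

Among the measured compounds shown here, only one measured step bears on this place, a 30-fold lower number from compound 1 to compound 2 (1.48 log units; beyond the scatter), and it was large and beyond the scatter. It shows that a swap here can move the number a long way, but it involved acetoxy, so it fixes no exact size for the new group. A rise of moderate size is expected, smaller than that step. The estimated move is a 4.9-fold higher number from compound 2 to compound 3 (0.69 log units; beyond the scatter), and it remains uncertain. The expected value for compound 3 is 60000 nM (15000 nM to 240000 nM) .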

Compound 3, solubility: 2300 nM
Beside the measured number, compound 3's estimate is 26-fold (1.42 log units) above it; measured number outside the range, below it.
By their numbers in this assay, from the lowest: compound 3; then compound 2; then compound 1.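

In this assay, replacing 1H-imidazol-1-yl with methanesulfonamido gives a 5.3-fold lower number from compound 2 to compound 3 (0.73 log units; beyond the scatter), even though the two groups hold the same number of heavy atoms. Against acetoxy, methanesulfonamido gives a 160-fold lower number from compound 1 to compound 3 (2.21 log units; beyond the scatter), so both replacements of acetoxy on this saturated chain carbon lower the number, and methanesulfonamido lowers it further than 1H-imidazol-1-yl. No measurement shown accounts for this order.

From the compounds shown here alone, it remains open whether the high number of compound 1 is particular to acetoxy or would also appear with other groups on this carbon, such as an amine, a carboxylic acid or a longer chain. A methanesulfonamido group carrying a methyl in place of the amide hydrogen would show whether that hydrogen has any bearing on the number.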